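The source may report more compounds than this note shows. Statements on the series, on what has been measured and on what is new or still open speak of the compounds shown alone.

Measured compounds in an ADME assay on MDBK cells (Bos taurus) for cytotoxicity, read by MTT assay, with a stated time of 96 h; on this read-out lower numbers stand for higher toxicity in this test and higher numbers for lower toxicity in this test:
compound 1 `CC(=O)Nc1ccc(-c2nc3cc(C(F)(F)F)ccc3n2C2CCCCC2)cc1`, 17000 nM;
compound 2 `CCN(CC)CC(=O)Nc1ccc(-c2nc3cc(C(F)(F)F)ccc3n2C)cc1`, 57000 nM;
compound 3 `Cn1c(-c2ccc(NC(=O)CN3CCCCC3)cc2)nc2cc(C(F)(F)F)ccc21`, 100000 nM.

Compound 3 gives the highest number of the three in this assay; compound 2 sits nearest, within the scatter, and compound 1 sits furthest, beyond the scatter. Compound 4 `CC(=O)Nc1ccc(-c2nc3cc(C(F)(F)F)ccc3n2C)cc1` is unmeasured. Its difference from compound 3: hydrogen in place of piperidin-1-yl on a saturated chain carbon bound to a carbonyl carbon. Among the measured compounds shown here, the only step at the same place, a 1.8-fold higher number from compound 2 to compound 3 (0.24 log units; within the scatter), exchanged one amine for another and stayed within the scatter; no measured step removes the amine outright. The acetamido group of compound 4 also sits in compound 1, on a core that differs from that of compound 4; compound 1 gives 17000 nM, a lower number than compound 3. For compound 4 a step of a 2.5-fold lower number from compound 3 to compound 4 (0.40 log units; beyond the scatter) toward lower numbers is therefore expected, with wide uncertainty. Compound 4 is estimated at 40000 nM, with a range from 12000 nM to 120000 nM.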

Compound 4, half-maximal cytotoxic concentration: 46000 nM
Estimate against measurement, compound 4: 1.2-fold (0.06 log units) below; the range from low to high includes it.
By their numbers in this assay, from the lowest: compound 1; then compounds 4, 2 and 3 (each within the scatter of the next, the first and the last beyond it).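

In this assay the amine on the saturated chain carbon bound to a carbonyl carbon is now removed outright, and the outcome differs by amine: a 2.2-fold lower number from compound 3 to compound 4 (0.34 log units; beyond the scatter) with piperidin-1-yl leaving, against a 1.2-fold lower number from compound 2 to compound 4 (0.09 log units; within the scatter) with diethylamino leaving. The series also gains a reading on the aromatic nitrogen, with methyl in place of cyclohexyl: a 2.7-fold higher number from compound 1 to compound 4 (0.43 log units; beyond the scatter). Nothing at hand accounts for either change.

Open, as far as these compounds go, is how a morpholine or a primary amine at the chain carbon would read. Also open, from the compounds shown here alone, is how an ethyl or a longer alkyl chain on the aromatic nitrogen would read.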